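The compounds below may be only part of what the source reports. "The series", "measured", "known", "first", "only" and "open" are said of these compounds alone.

Measured so far in an assay on isolated protein for displacement of a labelled ligand from Gonadotropin-releasing hormone receptor (Rattus norvegicus); a higher number here means a weaker inhibitor, a lower number a stronger inhibitor:
compound 1 `Cn1cnc(CN2CCN(c3cccc4[nH]c(-c5ccc(C(C)(C)C)cc5)nc34)CC2)c1` gives 98 nM;
compound 2 `Cc1nc(C)c(CN2CCN(c3cccc4[nH]c(-c5ccc(C(C)(C)C)cc5)nc34)CC2)o1` gives 740 nM;
compound 3 `CCc1nc(CN2CCN(c3cccc4[nH]c(-c5ccc(C(C)(C)C)cc5)nc34)CC2)cn1C` gives 78 nM.

Compound 2 stands at the highest number of the three, with steps to both others beyond the scatter. Compound 4 `CCn1cc(CN2CCN(c3cccc4[nH]c(-c5ccc(C(C)(C)C)cc5)nc34)CC2)nc1C` differs from compound 2 in one place: 1-ethyl-2-methyl-1H-imidazol-4-yl in place of 2,4-dimethyl-1,3-oxazol-5-yl on a saturated chain carbon bound to an amine nitrogen in a ring.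

Going by the values given here, the steps that bear on this change are a 7.6-fold higher number from compound 1 to compound 2 (0.88 log units; beyond the scatter) and a 9.5-fold lower number from compound 2 to compound 3 (0.98 log units; beyond the scatter), both of which move between an oxazole and an imidazole at the same place and both lie beyond the scatter. Compound 1 and compound 3 differ only by a 1.3-fold lower number from compound 1 to compound 3 (0.10 log units; within the scatter), within the scatter. A drop of similar size is therefore expected for compound 4, an 8.2-fold lower number from compound 2 to compound 4 (0.91 log units; beyond the scatter). Compound 4 is estimated at 90 nM, range 40 nM to 220 nM.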

Compound 4, half-maximal inhibitory concentration: 51 nM
Beside the measured number, compound 4's estimate is 1.8-fold (0.25 log units) above it; the range from low to high includes it.
By their numbers in this assay, from the lowest: compounds 4, 3 and 1 (each within the scatter of the next); then compound 2.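

The 1-ethyl-2-methyl-1H-imidazol-4-yl group also clears the gap to the oxazole (a 15-fold lower number from compound 2 to compound 4 (1.16 log units; beyond the scatter)), so a third imidazole now stands apart from 2,4-dimethyl-1,3-oxazol-5-yl at this position. With a 1.5-fold lower number from compound 3 to compound 4 (0.18 log units; within the scatter) and a 1.9-fold lower number from compound 1 to compound 4 (0.28 log units; within the scatter) both within the scatter, the three imidazoles are not separated from one another, whichever of these alkyl groups they carry. Nothing available explains these steps.

Going by these compounds, whether the gap belongs to the oxazole ring or to its substituents remains open. So does the effect of an amine, a carboxylic acid or a longer chain on the imidazole.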